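This account rests on a few compounds, and the source may have more. Where it says the series, first, only, none or still open, it means among the compounds named here.

Compound 1 `CC(C)OC(=O)c1sc(Nc2ncccn2)nc1-c1ccccn1` gives 49800 nM in a toxicity assay on PH5CH cells (Homo sapiens) for cytotoxicity, read by MTT assay, with a stated time of 72 h; a higher number here means that more compound is tolerated, a lower number that less compound is tolerated; compound 2 `CC(C)OC(=O)c1sc(Nc2ncccn2)nc1-c1cnccn1` gives 50000 nM; compound 3 `CC(C)OC(=O)c1sc(Nc2ncccn2)nc1-c1ccncn1` gives 50000 nM.

Compound 3 stands level with compound 2 at the digits shown, the two together at the top of three numbers, and the step of a 1.0-fold higher number from compound 1 to compound 3 (0.00 log units; within the scatter) lies within the scatter. Compound 4 `CC(C)OC(=O)c1sc(Nc2ncccn2)nc1-c1ncccn1` differs from compound 3 in one place: pyrimidin-2-yl in place of pyrimidin-4-yl on an aromatic carbon. Every measured step swaps one six-membered aromatic ring for another at this same carbon, and each was flat: a 1.0-fold higher number from compound 1 to compound 2 (0.00 log units; within the scatter), a 1.0-fold higher number from compound 1 to compound 3 (0.00 log units; within the scatter) and no change at the digits printed from compound 2 to compound 3 (within the scatter). No step beyond the scatter is therefore expected in this assay. Compound 4 is estimated at 50000 nM, between 25000 nM and 100000 nM, a step of no change at the digits printed from compound 3 to compound 4 (within the scatter) that is expected to stay within the scatter.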

Compound 4, half-maximal cytotoxic concentration: 50000 nM
Compound 4: middle estimate and measured number agree at the digits printed; the range from low to high includes it.
By their numbers in this assay, from the lowest: compounds 1, 2, 3 and 4 (each within the scatter of the next).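

In this assay, pyrimidin-2-yl on the aromatic carbon next to the ring nitrogen gives no step beyond the scatter from any earlier ring (no change at the digits printed from compound 3 to compound 4 (within the scatter); no change at the digits printed from compound 2 to compound 4 (within the scatter); a 1.0-fold higher number from compound 1 to compound 4 (0.00 log units; within the scatter)). Four six-membered aromatic rings at this carbon now lie within the scatter of one another, including two with the same atoms joined differently. No evidence is available here to explain this flatness.

As far as these compounds go, it remains open whether phenyl, an amine, a carboxylic acid or a longer chain at this carbon would shift the number. From the compounds shown here alone, the isopropoxycarbonyl and (pyrimidin-2-yl)amino groups stay the same throughout, so any effect of changing them also remains open.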